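Moving the methyl on the sulfonyl pyridine

The source may report more compounds than this note shows. Statements on the series, on what has been measured and on what is new or still open speak of the compounds shown alone.

The series shares one core carrying a methylaminomethyl group and a fluoropyridyl group, with a variable sulfonyl pyridine. Compound 1 `CNCc1cn(S(=O)(=O)c2ccc(F)cn2)c(-c2cccnc2F)c1F`, compound 2 `CNCc1cn(S(=O)(=O)c2cncc(Cl)c2)c(-c2cccnc2F)c1F` and compound 3 `CNCc1cn(S(=O)(=O)c2cccnc2C)c(-c2cccnc2F)c1F` have been tested in a functional assay on the whole organism (strain Jcl:Sprague-Dawley) for inhibition, with Rattus norvegicus as the target, with stated times of 3 min and 3 h, at a dose of 1 mg/kg by the intravenous route; a lower number here means less inhibition, a higher number more inhibition at the dose given (going by the name of the read-out). In this assay compound 1 gives 87%, while compound 3 gives 92%; for compound 2 the result is "not determined" (no result reported), so no number is available for it. Compound 3 thus stands highest of the two numbers shown, but its nearest neighbour, compound 1, sits a number 5 percentage points higher from compound 1 to compound 3 (within the scatter), so the two cannot be told apart.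

Compound 4 `CNCc1cn(S(=O)(=O)c2ccc(C)nc2)c(-c2cccnc2F)c1F` has not yet been measured. It differs from compound 3 in one place: 6-methylpyridin-3-yl in place of 2-methylpyridin-3-yl on a sulfonyl sulfur. Among the measured compounds shown here, the only measured step that bears on this change is the one from compound 1 to compound 3, where a different pyridyl group was exchanged on the sulfonyl sulfur and the read-out moved a number 5 percentage points higher from compound 1 to compound 3 (within the scatter). Since that exchange left the inhibition essentially unchanged, the expected step for compound 4 is a number 4 percentage points lower from compound 3 to compound 4 (within the scatter), with no change beyond the scatter. Compound 4 is therefore estimated to give 88% in this assay, within a range from 75% to 96%.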

Compound 4, a percentage reported as inhibition, in the whole organism at one dose (the size of the read-out at that dose, not a potency): 97%
Compound 4: the middle estimate sits 9 percentage points below what was measured; the measured number lies above the stated range.
By their numbers in this assay, from the lowest: compounds 1, 3 and 4 (each within the scatter of the next).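

In this assay, the exchange of 2-methylpyridin-3-yl for 6-methylpyridin-3-yl on a sulfonyl sulfur gives a number 5 percentage points higher from compound 3 to compound 4 (within the scatter), which shows that relocating the methyl group, with the same atoms joined differently, produces no change that can be told from the scatter, whereas the earlier step had exchanged different pyridyl groups. The wider comparison gives a number 10 percentage points higher from compound 1 to compound 4 (within the scatter), so the 5-fluoropyridin-2-yl, 2-methylpyridin-3-yl and 6-methylpyridin-3-yl groups on this sulfonyl sulfur cannot be separated at the single dose given, and compound 2 cannot join the comparison without a number. No measurement is available that would explain the outcome at this position.

The compounds shown leave open whether a methoxy group or a carboxylic acid on the pyridine in place of the methyl, or a plain phenyl ring on the sulfonyl sulfur, would move this assay beyond the scatter. Going by these compounds, since this read-out reports the size of the inhibition at one dose and not a potency, it also remains open whether compound 3 and compound 4 would differ at a lower dose.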